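This account rests on a few compounds, and the source may have more. Where it says the series, first, only, none or still open, it means among the compounds named here.

Working notes on the series. Compound 1 `COc1ccc(-c2cnc3nc(N)nc(N4CCN(C(=O)c5ccccc5)CC4)c3n2)cc1OC` is the starting point here. Within the data shown here, in a functional assay on cells (T-cell, Homo sapiens) for inhibition (a higher number here means a weaker inhibitor, a lower number a stronger inhibitor), compound 1 gives 400 nM, the lowest of the two numbers measured so far. Compound 2 `COc1ccc(-c2cnc3nc(N)nc(NC4CCCC4)c3n2)cc1OC` gives 800 nM in this assay, and the gap between compound 1 and compound 2 lies within the scatter, so neither stands apart from the other. For compound 3 `CCOc1nc(N)nc2ncc(-c3ccc(OC)cc3)nc12` this assay reports only a limit, > 10000 nM, not a number. Compound 4 `COc1ccc(-c2cnc3nc(N)nc(N4CCN(C(=O)CCc5ccccc5)CC4)c3n2)cc1OC` differs from compound 1 by phenethyl in place of phenyl on a carbonyl carbon. Among the measured compounds shown here, no measured pair follows this kind of step, so nothing measured sets its size. The expectation is a step of about no change at the digits printed from compound 1 to compound 4 (within the scatter), nothing beyond the scatter. Compound 4 is therefore estimated at 400 nM in this assay, within 150 nM to 1100 nM.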

Compound 4, half-maximal inhibitory concentration: 100 nM
Compound 4: middle estimate off by 4.0-fold (0.60 log units), on the high side, and the stated range ends above it.
By their numbers in this assay, from the lowest: compound 4; then compounds 1 and 2 (each within the scatter of the next). At a limit, above all of these: compound 3.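

In this assay the carbonyl substituent proves sensitive to this change, with phenethyl in place of phenyl on a carbonyl carbon giving a 4.0-fold lower number from compound 1 to compound 4 (0.60 log units; beyond the scatter). Both groups carry one six-membered aromatic ring of carbon only and no hydrogen-bond donors or acceptors, so the step goes with the longer group, on this single pair. Nothing shown here bears on why the step arises. Open, as far as these compounds go, is whether a longer chain such as phenylpropyl on that carbonyl carbon goes further, and whether an amine in place of the aromatic ring keeps the number.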